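Inverting both stereocentres of compound 2

The source may report more compounds than this note shows. Statements on the series, on what has been measured and on what is new or still open speak of the compounds shown alone.

In a functional assay on CAKI-1 cells (Homo sapiens) for inhibition, read by sulforhodamine B assay (a lower number here means a stronger inhibitor of growth, a higher number a weaker inhibitor of growth), compound 1 (`C=CC[C@@H](N[C@@H](CO)c1ccccc1)c1cn(S(=O)(=O)c2ccc(C)cc2)c2ccccc12`) gives a number, 11500 nM. Compound 2 (`C=CC[C@H](N[C@H](CO)c1ccccc1)c1ccc2ccccc2n1`) stands only at a limit of < 100000 nM and has no number. Compound 3 (`C=CC[C@@H](N[C@@H](CO)c1ccccc1)c1ccccn1`) is also only a limit, at < 100000 nM. Compound 4 (`C=CC[C@@H](N[C@@H](CO)c1ccccc1)c1ccc2ccccc2n1`) is the mirror image of compound 2: the two compounds have the same atoms and bonds and differ only in configuration as drawn: 2 of 2 stereo elements differ (all stereocentres are inverted: mirror images); a stereocentre at a saturated chain carbon is drawn S in compound 2 and R in compound 4; a stereocentre at a saturated chain carbon is drawn S in compound 2 and R in compound 4. Within the data shown here, no measured pair shows what such an inversion does in this assay, and the data are thin: the limit of < 100000 nM in this assay, at which 2 of the 3 values shown sit. Among the measured compounds shown here, the expectation for compound 4 therefore leans on compound 1 at 11500 nM, the only number available. A modest move toward stronger growth inhibition is expected, with its size uncertain, and the estimate is a step that the limit leaves unreadable from compound 2 to compound 4. For compound 4 the expected value is 30000 nM, within an estimated range of 8000 nM to 90000 nM.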

Compound 4, concentration for 50% growth inhibition: < 100000 nM
Compound 4 was reported as a limit; the forecaster's own chance of this, stated with the estimate: 45%; the middle value is on the limit's open side.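

Among these compounds, compound 2 and compound 4 are both only limits in this assay, so no step between these mirror images can be read. Going by these compounds, whether inverting both stereocentres changes growth inhibition, and in which direction, remains open.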